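A few compounds are considered here, and "the series" means these few. Any claim that something is new, unique, unknown or untested is made for them only; others in the source may bear on it.

Of the compounds shown here, three built on one shared core have been measured in an assay on CHO cells for antagonist activity at transient receptor potential cation channel subfamily V member 1 (Homo sapiens), read by FLIPR; on this read-out higher numbers stand for weaker inhibition and lower numbers for stronger inhibition. Compound 1 `CC(C)CCOc1cc(C(F)(F)F)ccc1CNC(=O)C(C)c1ccc(NS(C)(=O)=O)c(F)c1` gives 0.5 nM, compound 2 `CC(C(=O)NCc1ccc(C(F)(F)F)cc1OC1CCCCC1)c1ccc(NS(C)(=O)=O)c(F)c1` gives 0.7 nM, and compound 3 `CC(C(=O)NCc1ccc(C(F)(F)F)cc1OCc1ccccc1)c1ccc(NS(C)(=O)=O)c(F)c1` gives 0.9 nM. Compound 3 holds the highest of the three numbers, yet the steps of a 1.8-fold higher number from compound 1 to compound 3 (0.26 log units; within the scatter) and a 1.3-fold higher number from compound 2 to compound 3 (0.11 log units; within the scatter) both lie within the scatter, so the three cannot be told apart. Compound 4 `CC(C)CCSc1cc(C(F)(F)F)ccc1CNC(=O)C(C)c1ccc(NS(C)(=O)=O)c(F)c1` differs from compound 3 by isopentylsulfanyl in place of benzyloxy on an aromatic carbon. Among the measured compounds shown here, the steps that bear on this are the exchanges at the same position, a 1.4-fold higher number from compound 1 to compound 2 (0.15 log units; within the scatter), a 1.8-fold higher number from compound 1 to compound 3 (0.26 log units; within the scatter) and a 1.3-fold higher number from compound 2 to compound 3 (0.11 log units; within the scatter), all within the scatter; no measured step swaps oxygen for sulfur. The number for compound 4 is therefore expected to stay within the scatter, an estimated step of a 1.3-fold lower number from compound 3 to compound 4 (0.11 log units; within the scatter). Compound 4 is estimated at 0.7 nM, ranging from 0.2 nM to 2.5 nM.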

Compound 4, inhibition constant: 1.4 nM
Beside the measured number, compound 4's estimate is 2.0-fold (0.30 log units) below it; the range from low to high includes it.
By their numbers in this assay, from the lowest: compounds 1, 2, 3 and 4 (each within the scatter of the next, the first and the last beyond it).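

Swapping the oxygen of isopentyloxy for sulfur, with the isopentyl chain kept, gives the first step in this series beyond the scatter, though a modest one (a 2.8-fold higher number from compound 1 to compound 4 (0.45 log units; beyond the scatter)). The exchanges from benzyloxy (a 1.6-fold higher number from compound 3 to compound 4 (0.19 log units; within the scatter)) and from cyclohexyloxy (a 2.0-fold higher number from compound 2 to compound 4 (0.30 log units; within the scatter)) stay within the scatter, so only the exchange that keeps the chain separates two compounds. Nothing available explains this difference.

On these data alone, it remains open whether benzylsulfanyl or cyclohexylsulfanyl would follow their oxygen counterparts in the same way. An amine linking the isopentyl chain to the aromatic carbon is also untested among the compounds shown.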